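Notes on the step from compound 3 to compound 4

The source may hold more compounds than are shown below. What is called first, only, known or untested is meant among the compounds shown, and "the series" means these compounds.

Compound 1 `CCSc1nnc(-c2cc(OC)c(OC)c(OC)c2)n1-c1ccc(N(C)C)cc1`: 46200 nM
Compound 2 `COc1cc(-c2nnc(SCc3ccc(C)cc3)n2-c2ccc(N(C)C)cc2)cc(OC)c1OC`: 37300 nM
Compound 3 `COc1ccc(C(=O)CSc2nnc(-c3cc(OC)c(OC)c(OC)c3)n2-c2ccc(N(C)C)cc2)cc1O`: > 100000 nM, a limit

All three values come from a functional assay on PC-3 cells (Homo sapiens) for inhibition, read by MTT assay, with a stated time of 48 h; on this read-out lower numbers stand for stronger inhibition and higher numbers for weaker inhibition. Compound 3 stands at the limit of > 100000 nM in this assay, at which 1 of the 3 values shown sits, so it has a limit and no number.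

Compound 4 `CCOC(=O)CSc1nnc(-c2cc(OC)c(OC)c(OC)c2)n1-c1ccc(N(C)C)cc1` differs from it as follows: ethoxy in place of 3-hydroxy-4-methoxyphenyl on a carbonyl carbon. The end group thus goes from (3-hydroxy-4-methoxyphenyl)carbonyl to ethoxycarbonyl.

Two kinds of step bear on this. Methyl to 4-methylphenyl gave a 1.2-fold lower number from compound 1 to compound 2 (0.09 log units; within the scatter). The (3-hydroxy-4-methoxyphenyl)carbonyl group gave an at least 2.1-fold higher number from compound 1 to compound 3 (0.33 log units; beyond the scatter) and an at least 2.6-fold higher number from compound 2 to compound 3 (0.42 log units; beyond the scatter). With that group gone, a return towards compound 1 at 46200 nM is expected, though the carbonyl stays. The expected step is an at least 1.8-fold lower number from compound 3 to compound 4 (0.25 log units; that floor lies within the scatter). Compound 4 is estimated at 55000 nM, with an expected range of 22000 nM to 100000 nM.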

Compound 4, half-maximal inhibitory concentration: > 60000 nM
Compound 4: only a limit was reported (the forecaster's own chance of this, stated with the estimate: 25%); middle value at least 1.0-fold (0.03 log units) from the limit.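

In this assay, the limit for compound 4 is > 60000 nM. Against the simple chain ends, the ethoxycarbonyl group gives an at least 1.2-fold higher number from compound 1 to compound 4 (0.11 log units; that floor lies within the scatter) and an at least 1.6-fold higher number from compound 2 to compound 4 (0.20 log units; that floor lies within the scatter), so it is not shown to differ from methyl or 4-methylphenyl, although compound 3 and compound 4, the two carbonyl compounds, both end at limits. The step between those two cannot be read, so the 3-hydroxy-4-methoxyphenyl to ethoxy change has no size here.

On these data alone, the true value of compound 4 stays open. So does the effect of a carboxylic acid or an amine in place of ethoxy on this carbonyl carbon.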